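The source may hold more compounds than are shown below. What is called first, only, known or untested is meant among the compounds shown, and "the series" means these compounds.

Compound 2 `CCCCCCCC/C=C\c1c(C)c(/C=C\CCCCCCCC)c2[n+](c1C)CCC2` gives 3.3 uM in a functional assay on M12 cells (Homo sapiens) for antiproliferative activity, read by WST assay, with a stated time of 72 h (on this read-out lower numbers stand for an effect already at smaller amounts and higher numbers for an effect only at larger amounts of compound), at the upper end of the three numbers, though compound 1 `CCCCCCCC/C=C\c1c(C)c(/C=C/CCCCCCCC)c2[n+](c1C)CCC2` with 2.2 uM and compound 3 `CCCCCCCCCCc1c(C)c(CCCCCCCCCC)c2[n+](c1C)CCC2` with 1.9 uM both sit within the scatter of it. Among the measured compounds shown here, the only measured step that alters a single feature, a 1.5-fold higher number from compound 1 to compound 2 (0.18 log units; within the scatter), rests on the fact that compounds 1 and 2 differ only in the configuration as drawn alone. Compound 4 `CCCCCCCC/C=C\c1c(C)cc(C)[n+]2c1CCC2` differs from compound 2 in another way: hydrogen in place of dec-1-en-1-yl on an aromatic carbon. For the measured compounds named here, no measured pair trades a dec-1-en-1-yl group for hydrogen, so the step from compound 2 to compound 4 has no precedent among the measured compounds, and the configuration step cannot guide it. Loss of the dec-1-en-1-yl chain is nonetheless expected to move the number upward, a 2.1-fold higher number from compound 2 to compound 4 (0.33 log units; beyond the scatter). Compound 4 is therefore estimated at 7 uM, within 2.5 uM to 20 uM.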

Compound 4, concentration for half-maximal effect: 1.3 uM
Compound 4: the middle estimate sits 5.4-fold (0.73 log units) above what was measured; the measured number lies below the stated range.
By their numbers in this assay, from the lowest: compounds 4, 3, 1 and 2 (each within the scatter of the next, the first and the last beyond it).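

In this assay hydrogen in place of dec-1-en-1-yl on this aromatic carbon gives a 2.5-fold lower number from compound 2 to compound 4 (0.40 log units; beyond the scatter) and so the effect of compound 4 does not depend on that chain at this position. Among the steps shown, this is the only one that lies beyond the scatter. Nothing in the data shown accounts for its direction.

Going by these compounds, whether a shorter chain, a methyl group or an amine at this position would keep the number remains open. So does whether the remaining dec-1-en-1-yl group of compound 4 could also give way to hydrogen.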